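This account rests on a few compounds, and the source may have more. Where it says the series, first, only, none or still open, it means among the compounds named here.

Measured in an in vitro ADME assay on microsomes from liver (Homo sapiens) for metabolic stability, tested at 1 mg/mL; a higher number here means that the compound lasts longer, a lower number that the compound disappears faster:
- compound 1 `CC(C)C[C@@H](N)C(=O)Nc1cc2cc[nH]c(=O)c2cc1Cl`: 0.267 h
- compound 2 `CC(C)[C@H](N)C(=O)Nc1cc2cc[nH]c(=O)c2cc1Cl`: 1.48 h

Compound 2, at 1.48 h, has the higher of the two numbers, and compound 1 sits clearly under it. The next structure, compound 3 `CN1CCC(C(=O)Nc2cc3cc[nH]c(=O)c3cc2Cl)CC1`, places 1-methylpiperidin-4-yl in place of 1-amino-2-methylpropyl on a carbonyl carbon.

Among the measured compounds shown here, only one measured step bears on this change, at the same place on the molecule: a 5.5-fold higher number from compound 1 to compound 2 (0.74 log units; beyond the scatter). It shows that this assay can respond to a swap of this group. However, that step links two open chains, and neither measured compound has a ring here, so it gives only a rough guide to size and none to direction. With compound 2 at the top of so short a series, a small drop seems likeliest. The estimated change is a 1.9-fold lower number from compound 2 to compound 3 (0.27 log units; within the scatter). Compound 3 is expected at 0.8 h, with an estimated range of 0.25 h to 2.5 h.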

Compound 3, half-life: > 5 h
Compound 3 gave a limit, no number (the forecaster's own chance of this, stated with the estimate: 5%); middle value at least 6.2-fold (0.79 log units) away from the limit.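

Compound 3 reaches a limit in this assay and so gives no exact number: the limit of > 5 h in this assay, at which 1 of the 3 values shown sits.

Even so, the result shows that a ring on this carbonyl carbon can last longer than either open chain: 1-methylpiperidin-4-yl in place of 1-amino-2-methylpropyl gives an at least 3.3-fold higher number from compound 2 to compound 3 (0.52 log units; beyond the scatter), and in place of 1-amino-3-methylbutyl it gives an at least 18-fold higher number from compound 1 to compound 3 (1.27 log units; beyond the scatter). The earlier pair showed only that this position responds when one open chain replaces another, whereas these steps show a rise on moving to a ring, and each is only a lower bound on the true size.

This change alters the ring, the methyl on nitrogen and the hydrogen-bond donor count all at once, so the compounds shown cannot separate these features. From the compounds shown here alone, it stays open whether piperidin-4-yl without the methyl, or a cyclohexyl ring with no nitrogen, would last as long.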